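Methyl in place of trifluoromethyl: an expected small step

A few compounds are considered here, and "the series" means these few. Any claim that something is new, unique, unknown or untested is made for them only; others in the source may bear on it.

Compound 1 `NC(=O)c1c(NC(=O)c2ccccc2)sc2c1CCN(C(=S)Nc1ccccc1Cl)C2` gives 13800 nM in a functional assay on HL-60 cells (Homo sapiens) for antiproliferative activity, with a stated time of 24 h; a lower number here means a stronger inhibitor, a higher number a weaker inhibitor.
Compound 2 `NC(=O)c1c(NC(=O)c2ccccc2C(F)(F)F)sc2c1CCN(C(=S)Nc1ccccc1Cl)C2` gives 17600 nM in this assay.

Compound 2 and compound 1 lie within the scatter of each other, as the step of a 1.3-fold higher number from compound 1 to compound 2 (0.11 log units; within the scatter) shows; neither can be called the stronger. Compound 3 `Cc1ccccc1C(=O)Nc1sc2c(c1C(N)=O)CCN(C(=S)Nc1ccccc1Cl)C2` differs from compound 2 by methyl in place of trifluoromethyl on an aromatic carbon. Among the measured compounds shown here, the only step that bears on this change is a 1.3-fold higher number from compound 1 to compound 2 (0.11 log units; within the scatter), where trifluoromethyl entered at the same place and the number hardly moved. On that basis compound 3 is expected to show no step beyond the scatter, a 1.2-fold lower number from compound 2 to compound 3 (0.07 log units; within the scatter). Compound 3 is therefore estimated at 15000 nM in this assay, with a range from 7000 nM to 32000 nM.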

Compound 3, half-maximal inhibitory concentration: 20900 nM
Beside the measured number, compound 3's estimate is 1.4-fold (0.14 log units) below it, and the stated range covers the measured number.
By their numbers in this assay, from the lowest: compounds 1, 2 and 3 (each within the scatter of the next).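

Methyl in place of trifluoromethyl, the change from 2-(trifluoromethyl)phenyl to 2-methylphenyl, gives a 1.2-fold higher number from compound 2 to compound 3 (0.07 log units; within the scatter) in this assay, and methyl in place of hydrogen gives a 1.5-fold higher number from compound 1 to compound 3 (0.18 log units; within the scatter) at the same place. Hydrogen, trifluoromethyl and methyl, ortho to a large group, thus all lie within the scatter of one another, so this assay does not separate these three groups at this position. No available evidence offers a reason for this result.

Going by these compounds, whether an amine or a carboxylic acid at this position would give a step beyond the scatter remains open. So does whether these same groups would behave alike elsewhere on this six-membered aromatic ring.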